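The source may hold more compounds than are shown below. What is called first, only, known or untested is meant among the compounds shown, and "the series" means these compounds.

For the measured compounds named here, the three compounds measured so far share one core and differ only in a single group on one of its aromatic rings. Compound 1 `CC1=NNC(=O)C1C(c1c(-c2ccccc2)[nH]c2ccc(C)cc12)c1c(-c2ccccc2)[nH]c2ccc(Cl)cc12` carries a chloro there, compound 2 `COc1ccc2[nH]c(-c3ccccc3)c(C(c3c(-c4ccccc4)[nH]c4ccc(C)cc34)C3C(=O)NN=C3C)c2c1` a methoxy and compound 3 `CC1=NNC(=O)C1C(c1c(-c2ccccc2)[nH]c2ccccc12)c1c(-c2ccccc2)[nH]c2ccc(C)cc12` a hydrogen. In a functional assay on A549 cells (Homo sapiens) for cytotoxicity, read by MTT assay (on this read-out higher numbers stand for weaker inhibition and lower numbers for stronger inhibition), compound 1 gives 35000 nM, compound 2 gives 1800 nM and compound 3 gives 22100 nM. Compound 1 thus stands at the highest number of the three: the nearest neighbour is reached by a 1.6-fold lower number from compound 1 to compound 3 (0.20 log units; within the scatter), while the widest gap is a 19-fold lower number from compound 1 to compound 2 (1.29 log units; beyond the scatter).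

Compound 4 `CC1=NNC(=O)C1C(c1c(-c2ccccc2)[nH]c2ccc(Cl)cc12)c1c(-c2ccccc2)[nH]c2ccc(Cl)cc12` is made from compound 1 by chloro in place of methyl on an aromatic carbon, so that the molecule now carries two chloro groups. Going by the values given here, no measured step swaps a methyl for a chloro at that place. The closest guide is a 1.6-fold lower number from compound 1 to compound 3 (0.20 log units; within the scatter), which shows that taking a chloro off the core elsewhere barely moves the number. A step within the usual scatter is therefore expected, and a 1.2-fold lower number from compound 1 to compound 4 (0.07 log units; within the scatter) is the step that this expectation means. Compound 4 is estimated to give 30000 nM in this assay, with an expected range from 12000 nM to 80000 nM.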

Compound 4, half-maximal inhibitory concentration: 7000 nM
The estimate for compound 4 lay 4.3-fold (0.63 log units) above the measured number; measured number below the stated range.
By their numbers in this assay, from the lowest: compound 2; then compound 4; then compounds 3 and 1 (each within the scatter of the next).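

The place that holds the methyl in compounds 1, 2 and 3 turns out to matter: in this assay, chloro in place of that methyl gives a 5.0-fold lower number from compound 1 to compound 4 (0.70 log units; beyond the scatter). Until now, only the other substituted place had been varied, where hydrogen in place of chloro gave a step within the scatter, a 1.6-fold lower number from compound 1 to compound 3 (0.20 log units; within the scatter). Changes at this second place can therefore move the number beyond the scatter, although no information here explains why this one does.

With only methyl and chloro shown at this place, it remains open whether chloro lowers the number or methyl raises it, a question that hydrogen there could help settle. Also open, as far as these compounds go, is how methoxy, an amine or a carboxylic acid would behave at this place.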